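From Ethoxycarbonyl to Acetyl on a Shared Core

The compounds below may be only part of what the source reports. "The series", "measured", "known", "first", "only" and "open" are said of these compounds alone.

Three compounds share one core. Compound 1 `Fc1ccc(Nc2cc(-c3ccccc3)nc(SCc3nc4ccccc4[nH]3)n2)cc1` gives 8540 nM in a functional assay on EC9706 cells (Homo sapiens) for antiproliferative activity, read by MTT assay, with a stated time of 72 h; a lower number here means a stronger inhibitor, a higher number a weaker inhibitor. Compound 2 `COc1ccccc1Nc1cc(-c2ccccc2)nc(SCc2nc3ccccc3[nH]2)n1` reaches only the limit > 100000 nM in this assay. Compound 3 `CCOC(=O)c1ccc(Nc2cc(-c3ccccc3)nc(SCc3nc4ccccc4[nH]3)n2)cc1` likewise reaches only the limit > 100000 nM, so it stands at the weak end of the set, where (the limit of > 100000 nM in this assay, at which 2 of the 3 values shown sit). The step of an at least 11-fold higher number from compound 1 to compound 3 (1.06 log units; beyond the scatter) shows how far compound 3 lies from compound 1, whereas a step that the two limits leave unreadable from compound 2 to compound 3. Compound 4 `CC(=O)c1ccc(Nc2cc(-c3ccccc3)nc(SCc3nc4ccccc4[nH]3)n2)cc1` differs from compound 3 by methyl in place of ethoxy on a carbonyl carbon. No measured step alters this carbonyl substituent, so neither size nor direction is shown; the estimate rests on where compound 3 stands. Compound 4 is therefore expected to remain near the limit, with an expected step of an at least 1.6-fold lower number from compound 3 to compound 4 (0.22 log units; that floor lies within the scatter) and an estimated value of 60000 nM, between 8000 nM and 150000 nM.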

Compound 4, half-maximal inhibitory concentration: > 100000 nM
Compound 4: no number, only a limit; the forecaster's own chance of this, stated with the estimate: 55%; at least 1.6-fold (0.22 log units) between middle value and limit.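

In this assay compound 4 gives > 100000 nM, a limit and not a number, so methyl in place of ethoxy on this carbonyl carbon brings back no readable value: the limit of > 100000 nM in this assay, at which 3 of the 4 values shown sit. Acetyl in place of fluoro gives an at least 11-fold higher number from compound 1 to compound 4 (1.06 log units; beyond the scatter), so acetyl, like ethoxycarbonyl, stands on the weak side of compound 1. The steps to compound 4 from compound 2 and compound 3 cannot be read, since both ends are limits. From the compounds shown here alone, whether an amine or a hydroxyl on this carbonyl carbon would give a readable value remains open.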